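The source may report more compounds than this note shows. Statements on the series, on what has been measured and on what is new or still open speak of the compounds shown alone.

Among the compounds with values here, compound 2 `CC(=O)Nc1ccc([C@@H](C)NC2CCN(CCCc3c[nH]c4ccc(-n5cnnc5)cc34)CC2)cc1` holds the higher of the two numbers measured so far in an assay on CHO cells for binding affinity to 5-hydroxytryptamine receptor 1B (Homo sapiens); on this read-out higher numbers stand for weaker inhibition and lower numbers for stronger inhibition: compound 2 gives 350 nM. Its closest relative, compound 1 `C[C@H](NC1CCN(CCCc2c[nH]c3ccc(-n4cnnc4)cc23)CC1)c1ccccc1`, carries a plain 1-phenylethyl group on the same amine nitrogen, and in this assay compound 1 gives 95 nM. The two differ only in that group, and the step between them is a 3.7-fold higher number from compound 1 to compound 2 (0.57 log units; beyond the scatter), so on these numbers compound 2 stands as the weaker binder.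

Compound 3 `CC(CO)(NC1CCN(CCCc2c[nH]c3ccc(-n4cnnc4)cc23)CC1)c1ccccc1` changes the same position again: 1-(hydroxymethyl)-1-phenylethyl in place of 1-(4-acetamidophenyl)ethyl on an amine nitrogen. Two things happen at once. The acetamido part of the 1-(4-acetamidophenyl)ethyl group, whose arrival was measured as a 3.7-fold higher number from compound 1 to compound 2 (0.57 log units; beyond the scatter), is gone, and a hydroxymethyl group now forms part of the new 1-(hydroxymethyl)-1-phenylethyl group. Within the data shown here, only the first part has a measured counterpart; no measured step speaks to the hydroxymethyl addition. Removing the acetamido group should pull the number back toward that of compound 1, while the added hydroxymethyl remains an open question. In this assay compound 3 is therefore expected to give about 150 nM, with a plausible range from 50 nM to 500 nM, which would mean an expected step of a 2.3-fold lower number from compound 2 to compound 3 (0.37 log units; beyond the scatter).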

Compound 3, half-maximal inhibitory concentration: 98 nM
Beside the measured number, compound 3's estimate is 1.5-fold (0.18 log units) above it; the measured number falls inside the stated range.
By their numbers in this assay, from the lowest: compounds 1 and 3 (each within the scatter of the next); then compound 2.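

The first new step, a 3.6-fold lower number from compound 2 to compound 3 (0.55 log units; beyond the scatter), is beyond the scatter, so in this assay the group on this amine nitrogen still matters: the number responds when 1-(hydroxymethyl)-1-phenylethyl replaces 1-(4-acetamidophenyl)ethyl. Within the data shown here, the second step answers what the earlier compounds could not, namely what the hydroxymethyl group brings on its own: a 1.0-fold higher number from compound 1 to compound 3 (0.01 log units; within the scatter) lies within the scatter, so 1-(hydroxymethyl)-1-phenylethyl and plain 1-phenylethyl cannot be told apart in this assay. No measurement here explains why the acetamido-bearing group stands apart from the other two, so these numbers describe the change without giving a cause.

As far as these compounds go, it remains open whether other groups in place of the hydroxymethyl, such as an aminomethyl group, a carboxylic acid or a longer hydroxyalkyl chain, would also leave the number level with that of compound 1, or whether the hydroxymethyl group would have the same lack of effect alongside the acetamido group. Also open, from the compounds shown here alone, is whether the two mirror-image forms of compound 3 would give different numbers, since its 1-(hydroxymethyl)-1-phenylethyl group carries no defined stereocentre.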